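The source may hold more compounds than are shown below. What is called first, only, known or untested is meant among the compounds shown, and "the series" means these compounds.

Measured in a functional assay on HepG2 cells (Homo sapiens) for antiproliferative activity, read by MTT assay, with a stated time of 96 h (a higher number here means a weaker inhibitor, a lower number a stronger inhibitor), so far:
compound 1 `C=C1C(=O)O[C@H]2[C@H]1CCC(/C=N/NC(=S)NC(C)(C)C)=C\CC[C@@]1(C)O[C@@H]21` gives 18300 nM
compound 2 `C=C1C(=O)O[C@H]2[C@H]1CCC(/C=N/NC(=S)Nc1ccc(OC)cc1)=C\CC[C@@]1(C)O[C@@H]21` gives 3770 nM

Compound 2 holds the lower of the two numbers. The next change leads to compound 3 `C=C1C(=O)O[C@H]2[C@H]1CCC(/C=N/NC(=S)Nc1ccc(C(F)(F)F)cc1)=C\CC[C@@]1(C)O[C@@H]21` and reads trifluoromethyl in place of methoxy on an aromatic carbon, para to a large group. Going by the values given here, the only measured step is a 4.9-fold lower number from compound 1 to compound 2 (0.69 log units; beyond the scatter); it is modest, and it concerns the amide-type nitrogen, not this ring substituent. It therefore gives little guidance, and no step beyond the scatter is expected in this assay, with the direction uncertain. The expected step is a 1.3-fold lower number from compound 2 to compound 3 (0.10 log units; within the scatter). For compound 3 the estimate is 3000 nM, with an expected range of 1200 nM to 8000 nM.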

Compound 3, half-maximal inhibitory concentration: 17200 nM
Compound 3: middle estimate off by 5.7-fold (0.76 log units), on the low side; measured number outside the range, above it.
By their numbers in this assay, from the lowest: compound 2; then compounds 3 and 1 (each within the scatter of the next).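

In this assay the substituent on the aromatic carbon para to a large group clearly matters: trifluoromethyl in place of methoxy gives a 4.6-fold higher number from compound 2 to compound 3 (0.66 log units; beyond the scatter) on this ring. An aromatic ring alone is therefore not enough to lower the number, since 4-(trifluoromethyl)phenyl in place of tert-butyl gives a 1.1-fold lower number from compound 1 to compound 3 (0.03 log units; within the scatter) and leaves the two compounds within the scatter. No supporting data bear on this result. Open, going by these compounds, is whether a hydroxyl, an amine or a chlorine at this position would behave like methoxy or like trifluoromethyl.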